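This account rests on a few compounds, and the source may have more. Where it says the series, first, only, none or still open, it means among the compounds named here.

Measurements so far come from an assay on isolated protein for binding affinity to interleukin-15 (Homo sapiens), read by surface plasmon resonance; on this read-out lower numbers stand for tighter binding and higher numbers for weaker binding. In this assay compound 2 `COc1ccc(NC(=O)CCCCCCCSc2nnc(Cc3nn(C)c(=O)c4ccccc34)n2C)cc1` gives 26000 nM. Compound 3 `CCCOc1ccc(NC(=O)CCCCCCCSc2nnc(Cc3nn(C)c(=O)c4ccccc34)n2C)cc1` gives 19000 nM. Compound 1 `Cn1c(Cc2nn(C)c(=O)c3ccccc23)nnc1SCCCCCCCC(=O)Nc1ccc(F)cc1F` gives "not determined" (no result reported).

Compound 3 has the lowest of the two numbers, but the measured step is a 1.4-fold lower number from compound 2 to compound 3 (0.14 log units; within the scatter), within the scatter, so the two cannot be ordered. Compound 4 `CC(C)Oc1ccc(NC(=O)CCCCCCCSc2nnc(Cc3nn(C)c(=O)c4ccccc34)n2C)cc1` differs from compound 3 by isopropyl in place of propyl on an oxygen on an aromatic ring. Among the compounds with values here, the only measured step that bears on this is the one from compound 2 to compound 3, the same oxygen carrying a longer alkyl group, and it stayed within the scatter. A rearrangement of the same alkyl group on that oxygen is therefore expected to give no step beyond the scatter in this assay, in either direction: no change at the digits printed from compound 3 to compound 4 (within the scatter). Compound 4 is estimated at 19000 nM, range 8000 nM to 45000 nM.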

Compound 4, dissociation constant: 20900 nM
Beside the measured number, compound 4's estimate is 1.1-fold (0.04 log units) below it; measured number inside the range.
By their numbers in this assay, from the lowest: compounds 3, 4 and 2 (each within the scatter of the next).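

Isopropyl in place of propyl on the oxygen gives a 1.1-fold higher number from compound 3 to compound 4 (0.04 log units; within the scatter), so the branched and straight groups cannot be told apart at this place. Isopropyl in place of methyl gives a 1.2-fold lower number from compound 2 to compound 4 (0.09 log units; within the scatter), which puts methyl, propyl and isopropyl on this oxygen all within the scatter of one another. No measurement at hand offers a reason for this.

Open, on these data alone, is whether an amine, a carboxylic acid or a longer chain on this oxygen would give a step beyond the scatter. Compound 1 has no reported result, so fluorine on the aromatic ring remains unread.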